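Swapping the furan attachment point on a shared core

A few compounds are considered here, and "the series" means these few. Any claim that something is new, unique, unknown or untested is made for them only; others in the source may bear on it.

Compound 1 `Oc1cccc(-c2cc(-c3ccsc3)cc(-c3ccccc3O)n2)c1` in a functional assay on HCT-15 cells (Homo sapiens) for cytotoxicity, read by CCK-8 assay; a higher number here means a weaker inhibitor, a lower number a stronger inhibitor: > 50000 nM, a limit of the assay.
Compound 2 `Oc1ccccc1-c1cc(-c2ccco2)cc(-c2ccccc2O)n1` in this assay: > 50000 nM, a limit of the assay.
Compound 3 `Oc1cccc(-c2cc(-c3ccco3)cc(-c3ccccc3O)n2)c1` in this assay: > 50000 nM, a limit of the assay.

Compound 3 stands at the same place as every other measured compound: not at a number, but at a limit, and the limit of > 50000 nM in this assay, at which 3 of the 3 values shown sit, sums up the whole measured set. Two steps lead to compound 3, a step that the two limits leave unreadable from compound 1 to compound 3 and a step that the two limits leave unreadable from compound 2 to compound 3, and neither can be read, since both ends of each step are limits.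

Compound 4 `Oc1cccc(-c2cc(-c3ccoc3)cc(-c3ccccc3O)n2)c1` differs from compound 3 in one place: furan-3-yl in place of furan-2-yl on an aromatic carbon. The two steps that bear on this change, a step that the two limits leave unreadable from compound 1 to compound 3 and a step that the two limits leave unreadable from compound 2 to compound 3, are unreadable, so they give no size in either direction. With every measured value at the limit, compound 4 is expected to stay there as well, and a step that the limit leaves unreadable from compound 3 to compound 4 is expected to be no step beyond the scatter. The estimate for compound 4 in this assay is 60000 nM, with a range from 20000 nM to 200000 nM, most likely reported again only as a limit.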

Compound 4, half-maximal inhibitory concentration: > 50000 nM
Compound 4: a limit, no number; the forecaster's own chance of this, stated with the estimate: 85%; the middle value does not contradict the limit.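

Compound 4 in this assay gives > 50000 nM, a limit of the assay and not a number. The steps to it from compound 3 and from compound 1 join two limits and cannot be read. Whether furan-3-yl and furan-2-yl differ at all on the shared core stays open, and so does what would give a readable number, with the whole set at one ceiling: the limit of > 50000 nM in this assay, at which 4 of the 4 values shown sit.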